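Bromo removal on the salicylanilide core: expected cytotoxicity

The compounds below may be only part of what the source reports. "The series", "measured", "known", "first", "only" and "open" are said of these compounds alone.

Compound 1 `O=C(Nc1cccc(Cl)c1)c1cc(Br)cc(Br)c1O` gives 18000 nM in an ADME assay on HEK293 cells (Homo sapiens) for cytotoxicity, read by reporter gene assay and resazurin assay, with a stated time of 48 h; on this read-out lower numbers stand for higher toxicity in this test and higher numbers for lower toxicity in this test. Compound 3 `O=C(Nc1cccc(Cl)c1)c1cccc(Br)c1O` is obtained from it by hydrogen in place of bromo on an aromatic carbon, and in this assay compound 3 gives 32000 nM; the step of a 1.8-fold higher number from compound 1 to compound 3 (0.25 log units; within the scatter). Compound 2 `O=C(Nc1ccc(Sc2nc3ccccc3s2)c(Cl)c1)c1cc(Br)ccc1O` carries a different core; how the two cores differ is not broken down here. In this assay compound 2 gives 45000 nM, a higher number than that of compound 1, while the numbers of compound 2 and compound 3 lie within the scatter of each other.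

Compound 4 `O=C(Nc1ccc(Sc2nc3ccccc3s2)c(Cl)c1)c1ccccc1O` is not yet measured. It arises from compound 2 by hydrogen in place of bromo on an aromatic carbon. This is the same kind of change as from compound 1 to compound 3, not the same: there the place was also meta to a bromo group, here it is not. The expected step in this assay is a 1.3-fold higher number from compound 2 to compound 4 (0.12 log units; within the scatter), beside the measured 1.8-fold higher number from compound 1 to compound 3 (0.25 log units; within the scatter), and rests on the small size of that measured step. Compound 4 is therefore estimated at 60000 nM, in the range 30000 nM to 120000 nM.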

Compound 4, half-maximal cytotoxic concentration: 64000 nM
Compound 4: middle estimate off by 1.1-fold (0.03 log units), on the low side; measured number inside the range.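

In this assay, hydrogen in place of bromo gives a 1.4-fold higher number from compound 2 to compound 4 (0.15 log units; within the scatter), a step that stays within the scatter, as does the earlier step on the other core. On these two cores the change carries over as a small step, and the two steps cannot be told apart: the same change on two cores in this assay, a 1.8-fold higher number (0.25 log units; within the scatter) from compound 1 to compound 3 and a 1.4-fold higher number (0.15 log units; within the scatter) from compound 2 to compound 4, 1.3-fold (0.10 log units) apart, within the scatter of two such steps. For the compounds shown here, this does not show that the change is without effect across the series: only two pairs stand here, neither step is beyond the scatter, and compound 3 keeps a bromo group on the ring whereas compound 4 keeps none.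

Open, going by these compounds, is how the read-out responds when the place para to the hydroxy group carries something other than bromo or hydrogen, such as an amine or a carboxylic acid. Also open, on these data alone, is whether the step stays this small on a core without the chloro group or without the hydroxy group.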